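Hydrogen in place of fluoro on compound 2

This account rests on a few compounds, and the source may have more. Where it says the series, first, only, none or still open, it means among the compounds named here.

Measured in an ADME assay on U2OS cells (Homo sapiens) for cytotoxicity; on this read-out higher numbers stand for lower toxicity in this test and lower numbers for higher toxicity in this test:
- compound 1 `CC(C)(O)c1cc2c(-c3ccc(C#N)cc3)nccc2[nH]1`: "not determined" (no result reported)
- compound 2 `CC(C)(O)c1cc2c(-c3ccc(F)cc3)nccc2[nH]1`: 93600 nM

For the measured compounds named here, compound 2, at 93600 nM, carries the only number in this small set. Compound 1 has no result, so compound 2 cannot be ranked against anything, and its value stands alone as the single reference point.

The compound still to be measured is compound 3 `CC(C)(O)c1cc2c(-c3ccccc3)nccc2[nH]1`. It departs from compound 2 in one place: hydrogen in place of fluoro on an aromatic carbon. Hydrogen stands in place of fluoro on an aromatic carbon, and the rest of the structure is unchanged.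

Going by the values given here, no pair of measured compounds shows what such an exchange does in this assay, so the expectation rests only on the value of compound 2 and on the single change. No direction is favoured, and no step beyond the usual scatter is expected. The estimated size of the change is a 1.0-fold lower number from compound 2 to compound 3 (0.02 log units; within the scatter). In this assay, compound 3 is estimated at 90000 nM, with an expected range from 40000 nM to 180000 nM.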

Compound 3, half-maximal cytotoxic concentration: 22200 nM
The estimate for compound 3 lay 4.1-fold (0.61 log units) above the measured number, outside the stated range (below it).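

In this assay, hydrogen in place of fluoro on the aromatic carbon para to a large group gives a 4.2-fold lower number from compound 2 to compound 3 (0.62 log units; beyond the scatter), so this position is not indifferent to this exchange, and the compound without the fluoro group reads as the more toxic in this test. For the compounds shown here, this is the first readable step, as the nitrile-bearing compound 1, at "not determined" (no result reported), offers no comparison at the same position. Nothing available accounts for the size or direction of the step.

The compounds shown leave open whether fluoro is special at this position or whether other groups there, such as a methoxy group, an amine or a carboxylic acid, would read like compound 2, like compound 3 or differently from both. With a single pair, they also leave open whether the same exchange would give a similar step on another core or at another carbon of the six-membered aromatic ring.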